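Weak Cytotoxicity Throughout: Expecting Compound 4 at the Limit

This account rests on a few compounds, and the source may have more. Where it says the series, first, only, none or still open, it means among the compounds named here.

Measured compounds in an ADME assay on HCT-116 cells (Homo sapiens) for cytotoxicity, read by MTT assay, with a stated time of 72 h; a lower number here means a stronger inhibitor, a higher number a weaker inhibitor:
- Compound 1 `Cc1cccc(NC(=O)c2cccc(/C=C3\CC(=O)N(c4ccccc4)C3=O)c2)c1` gives > 100000 nM, which is a limit of the assay rather than a number.
- Compound 2 `O=C(Nc1ccc(OC(F)F)cc1)c1cccc(/C=C2\CC(=O)N(c3ccccc3)C2=O)c1` gives > 100000 nM, again a limit of the assay.
- Compound 3 `CCc1cccc(NC(=O)c2cccc(/C=C3\CC(=O)N(c4ccccc4)C3=O)c2)c1` gives 81200 nM, the only actual number among the three.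

All three compounds share one core and differ only in the aryl group on the amide nitrogen. Within the data shown here, compound 3 stands as the sole compound with a readable number; the other two sit at the limit (the limit of > 100000 nM in this assay, at which 2 of the 3 values shown sit). The step from compound 1 to compound 3 is an at least 1.2-fold lower number from compound 1 to compound 3 (0.09 log units; that floor lies within the scatter), and the step from compound 2 to compound 3 is an at least 1.2-fold lower number from compound 2 to compound 3 (0.09 log units; that floor lies within the scatter); both are floors that fall within the scatter, so compound 3 cannot be called more potent than the others. The step from compound 1 to compound 2 is a step that the two limits leave unreadable from compound 1 to compound 2.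

Compound 4 `COc1ccc(NC(=O)c2cccc(/C=C3\CC(=O)N(c4ccccc4)C3=O)c2)c(C)c1` differs from compound 3 in one place: 4-methoxy-2-methylphenyl in place of 3-ethylphenyl on an amide-type nitrogen. The new group carries a methyl, as the ring of compound 1 does, and an oxygen-linked substituent, as the ring of compound 2 does, and both of those compounds returned only a limit. Among the measured compounds shown here, nothing among the measured steps points to a change beyond the scatter, so the step from compound 3 to compound 4 is expected to be a 1.2-fold higher number from compound 3 to compound 4 (0.09 log units; within the scatter). Compound 4 is therefore estimated at 100000 nM, with a likely range from 50000 nM to 300000 nM, and a fair chance that this assay reports only a limit.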

Compound 4, half-maximal inhibitory concentration: > 100000 nM
Compound 4: only a limit was reported; the forecaster's own chance of this, stated with the estimate: 60%; the middle value lies on the limit itself.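

In this assay, among these compounds, putting 4-methoxy-2-methylphenyl in place of 3-ethylphenyl on the amide-type nitrogen gives an at least 1.2-fold higher number from compound 3 to compound 4 (0.09 log units; that floor lies within the scatter), so this change, which brings an oxygen into the group, produces no step that can be told apart from the scatter. Compound 4 gives > 100000 nM, which is a limit of the assay and not a number. The steps that join compound 4 to compound 1 and to compound 2 cannot be read, and this position now carries three different substituted phenyl groups that each return only a limit: the limit of > 100000 nM in this assay, at which 3 of the 4 values shown sit.

Going by these compounds, every group on this nitrogen is a substituted phenyl ring, so it remains open whether an amine or a carboxylic acid on that ring, or a chain longer than the ethyl of compound 3, would give a clearly lower number in this assay. The shared core is also the same in all four compounds, which leaves open what a change anywhere outside this one position would do.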